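Swapping a Tert-Butyl Amide for a Methylphenyl Amide

This account rests on a few compounds, and the source may have more. Where it says the series, first, only, none or still open, it means among the compounds named here.

Of the compounds shown here, two sharing one core have been tested in a functional assay on QGY7701 cells (Homo sapiens) for cytotoxicity, read by MTT assay, with a stated time of 24 h; a lower number here means a stronger inhibitor, a higher number a weaker inhibitor. Compound 1 `C=CC1=C(C(=O)NCc2ccc(Cl)cc2)C(c2ccc(OC)c(OC)c2)OC1` carries a 4-chlorobenzyl group on its amide nitrogen. In this assay compound 1 gives > 100000 nM, which is a limit of the assay and not a number. Compound 2 `C=CC1=C(C(=O)NC(C)(C)C)C(c2ccc(OC)cc2)OC1` carries a tert-butyl group on the same nitrogen. In this assay compound 2 gives > 100000 nM, again a limit rather than a number. Where compound 2 stands is therefore only this: it sits at the limit, as does the other value, at the limit of > 100000 nM in this assay, at which 2 of the 2 values shown sit. Going by the values given here, because both numbers are limits, no step between measured compounds can be read, and the size of any change remains unknown.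

Compound 3 `C=CC1=C(C(=O)Nc2ccc(C)cc2)C(c2ccc(OC)cc2)OC1` is not yet measured. It differs from compound 2 by 4-methylphenyl in place of tert-butyl on an amide-type nitrogen. With nothing measured beyond the limit, only a guess is possible. The step from compound 2 to compound 3, an at least 1.2-fold lower number from compound 2 to compound 3 (0.09 log units; that floor lies within the scatter), is expected to be small and most likely still within the limit. Compound 3 is estimated at 80000 nM, with a range from 20000 nM to 200000 nM.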

Compound 3, half-maximal inhibitory concentration: > 100000 nM
Compound 3: a limit, no number (the forecaster's own chance of this, stated with the estimate: 60%); middle value at least 1.2-fold (0.09 log units) away from the limit.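

In this assay compound 3 gives > 100000 nM, a limit of the assay and not a number. Compound 2 also sits at a limit, so no step can be read between compound 2 and compound 3: the limit of > 100000 nM in this assay, at which 3 of the 3 values shown sit.

The compounds shown leave open how far each lies past that limit, and whether any group on the amide nitrogen gives a readable number.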